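The source may report more compounds than this note shows. Statements on the series, on what has been measured and on what is new or still open speak of the compounds shown alone.

Measured compounds:
- compound 1, `Nc1nc(Cl)c2ncn(Cc3ccccc3CCl)c2n1`: 30900 nM
- compound 2, `Nc1nc(Cl)c2ncn(Cc3ccc(CCl)cc3)c2n1`: 7240 nM
- compound 3, `ClCc1ccccc1Cn1cnc2nc(Cl)nc(Cl)c21`: 3230 nM

In a functional assay on EKVX cells (Homo sapiens) for cytotoxicity, read by sulforhodamine B assay, with a stated time of 48 h (on this read-out higher numbers stand for weaker inhibition of growth and lower numbers for stronger inhibition of growth), compound 1 gives 30900 nM, the highest of the three numbers. Compound 2 gives 7240 nM, and compound 3 gives 3230 nM; both gaps from compound 1 lie beyond the usual scatter, so compound 1 is the weakest growth inhibitor of the three on this read-out. For the measured compounds named here, no single-point step between measured compounds is available, so the size of any step must be judged from these three values alone.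

Compound 4, `ClCc1ccccc1Cn1cnc2c(Cl)nc(Cl)nc21`, has not yet been measured. It differs from compound 1 in one place: chloro in place of amino on an aromatic carbon. Compound 3, which also carries two chloro groups on its core, gives the lowest number of the set, and this suggests that the step from compound 1 to compound 4 goes toward stronger inhibition. The expected step, a 6.9-fold lower number from compound 1 to compound 4 (0.84 log units; beyond the scatter), is beyond the scatter. Compound 4 is therefore expected to give about 4500 nM in this assay, within a range from 1500 nM to 14000 nM.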

Compound 4, concentration for total growth inhibition: 3230 nM
The estimate for compound 4 lay 1.4-fold (0.14 log units) above the measured number, and the stated range covers the measured number.
By their numbers in this assay, from the lowest: compounds 3 and 4 (each within the scatter of the next); then compound 2; then compound 1.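

For the compounds shown here, the step of a 9.6-fold lower number from compound 1 to compound 4 (0.98 log units; beyond the scatter) in this assay is the first reading of a change in one place, and it lies beyond the scatter, toward stronger inhibition of growth. Going by these compounds alone, it shows that this aromatic carbon between two ring nitrogen atoms is not indifferent to its substituent: chloro in place of amino alone shifts the number, which the earlier compounds could not show because none of them differed from another in one place. Nothing available accounts for the size of this step, so it stands as an observation without an explanation.

From the compounds shown here alone, with only amino and chloro seen at this position, it remains open whether a methoxy group, a dimethylamine or a plain hydrogen there would give a number nearer to that of compound 1 or compound 4. Going by these compounds, it also remains open whether the same exchange would give a step of like size on compound 2.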